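The source may hold more compounds than are shown below. What is called first, only, known or untested is meant among the compounds shown, and "the series" means these compounds.

Three quinolinone-derived hydrazones and imines were examined in a functional assay, read by spectrophotometry, with a stated time of 30 min; on this read-out lower numbers stand for stronger inhibition and higher numbers for weaker inhibition. Compound 1 `NS(=O)(=O)CC(=O)N/N=C/c1cc2ccccc2[nH]c1=O` gives 1290000 nM. Compound 2 `Cc1ccc2[nH]c(=O)c(/C=N/NC(=O)CS(N)(=O)=O)cc2c1` gives 3350000 nM. Compound 3 `Cc1ccc2[nH]c(=O)c(/C=N/Cc3ccccc3)cc2c1` gives "not active" (no number reported) in this assay, and no number is given for it. Compound 4 `O=c1[nH]c2ccccc2cc1/C=N/Cc1ccccc1` has not been measured.

Compounds 1 and 2 differ in one place, (hydrogen in place of methyl on an aromatic carbon), and this gave a 2.6-fold lower number from compound 2 to compound 1 (0.41 log units; beyond the scatter). Compound 3 and compound 2 differ across a larger part of the molecule; the difference between the two cores is not broken down here. Compound 4 differs from compound 3 by hydrogen in place of methyl on an aromatic carbon, and the place of the change is the same in both pairs, so it is the same change.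

Since compound 3 has no number, the step seen from compound 2 to compound 1 can only be applied to a compound described as not active. Compound 4 is therefore expected to remain very weak in this assay, most likely reported again without a number. Compound 4 is estimated at 5000000 nM, with a range from 1000000 nM to 30000000 nM.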

Compound 4, half-maximal inhibitory concentration: "not active" (no number reported)
For compound 4 the study gives words and no number; the estimate stays without a comparison.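

In this assay compound 3 and compound 4 are both reported as not active, without a number, so no step can be read between them. The compounds shown leave open whether hydrogen in place of methyl changes anything on this pair as it does from compound 2 to compound 1. No measured evidence bears on this result.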